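The compounds below may be only part of what the source reports. "The series", "measured", "known", "first", "only" and "open" are said of these compounds alone.

Measured compounds:
compound 1, `COc1cc(-c2nn(-c3cccc(NC(=O)c4cccc(C(F)(F)F)c4)c3)cc2-c2ccncc2)ccc1Cl`, 1640 nM
compound 2, `COc1cc(-c2nn(-c3cccc(NC(=O)Nc4cccc(C(F)(F)F)c4)c3)cc2-c2ccncc2)ccc1Cl`, 894 nM
compound 3, `COc1cc(-c2nn(-c3cccc(NC(=O)Nc4ccc(Cl)c(C(F)(F)F)c4)c3)cc2-c2ccncc2)ccc1Cl`, 711 nM

In a functional assay on COLO 205 cells (Homo sapiens) for inhibition, read by sulforhodamine B assay, with a stated time of 48 h (on this read-out higher numbers stand for weaker inhibition of growth and lower numbers for stronger inhibition of growth), compound 3 holds the lowest of the three numbers. Its nearest neighbour is compound 2: a 1.3-fold lower number from compound 2 to compound 3 (0.10 log units; within the scatter). The gap to compound 1 is larger: a 2.3-fold lower number from compound 1 to compound 3 (0.36 log units; beyond the scatter). The third measured step, a 1.8-fold lower number from compound 1 to compound 2 (0.26 log units; within the scatter), also concerns the group on the carbonyl carbon.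

Compound 4, `O=C(Nc1cccc(-n2cc(-c3ccncc3)c(-c3ccc(Cl)c(O)c3)n2)c1)Nc1ccc(Cl)c(C(F)(F)F)c1`, keeps the urea of compound 3 and differs only at the other end: hydrogen in place of methyl on an oxygen on an aromatic ring. Within the data shown here, none of the measured steps touches this oxygen; all three alter the group on the carbonyl carbon, so no measured step bears directly on the change from compound 3 to compound 4. With nothing to point either way, the expectation for compound 4 is a step no larger than the scatter, a 1.1-fold higher number from compound 3 to compound 4 (0.05 log units; within the scatter), and the range around it is kept wide. Compound 4 is therefore estimated at 800 nM in this assay, expected to lie between 300 nM and 2500 nM.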

Compound 4, concentration for 50% growth inhibition: 2390 nM
The estimate for compound 4 lay 3.0-fold (0.48 log units) below the measured number, and the stated range covers the measured number.
By their numbers in this assay, from the lowest: compounds 3, 2, 1 and 4 (each within the scatter of the next, the first and the last beyond it).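

The first change shown at this oxygen, methoxy to hydroxy, reads in this assay as a 3.4-fold higher number from compound 3 to compound 4 (0.53 log units; beyond the scatter) and so costs growth inhibition. The earlier steps shown here all altered the group on the carbonyl carbon, so they could not show that this end of the molecule is sensitive to change; here, the loss of one methyl from the oxygen is enough to shift the number beyond the scatter. No measurement available here explains why the hydroxy compound gives the higher number.

On these data alone, whether a longer chain on this oxygen, such as ethoxy, or an amine in place of the hydroxy would restore the number of compound 3 remains open. The hydroxy appears here only with the urea of compound 4, so it is also unknown whether the step would carry over to the amide of compound 1.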